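The source may hold more compounds than are shown below. What is called first, only, known or untested is meant among the compounds shown, and "the series" means these compounds.

Compound 2 `Cc1nc(C(NC(=O)C(=O)Nc2ccc(F)cc2)C2CCCCN2)sc1CO` is tested in an ADME assay on MT2 cells (Homo sapiens) for cytotoxicity, read by XTT assay, with a stated time of 4 days (a higher number here means that more compound is tolerated, a lower number that less compound is tolerated), where it reads > 113000 nM. That figure is a limit of the assay and not a number, so compound 2 has no exact position on the scale. For the measured compounds named here, the only exact reading nearby comes from compound 1 `Cc1ccc(NC(=O)C(=O)NC(c2nc(C)c(CCO)s2)C2CCCCN2)cc1F`, which gives 85000 nM in this assay.

The next molecule, compound 3 `Cc1nc(C(NC(=O)C(=O)Nc2ccc(F)cc2)C2CCCCN2)sc1CCO`, changes compound 2 in one place: hydroxymethyl in place of hydroxy on a saturated chain carbon bound to an aromatic carbon. In words, hydroxymethyl takes the place of hydroxy on a saturated chain carbon bound to an aromatic carbon, so the side chain goes from hydroxymethyl to 2-hydroxyethyl.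

Going by the values given here, no measured pair shows this change on its own in this assay. The closest guide is compound 1, which carries the same 5-(2-hydroxyethyl)-4-methyl-1,3-thiazol-2-yl group and gives 85000 nM, although it also differs elsewhere. A shift beyond the usual scatter is therefore not expected, and no direction is favoured. The expected step is an at least 1.0-fold lower number from compound 2 to compound 3 (0.01 log units; that floor lies within the scatter). For compound 3 the estimated value is 110000 nM, with an expected range from 60000 nM to 200000 nM.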

Compound 3, half-maximal cytotoxic concentration: 109000 nM
Compound 3: middle estimate off by 1.0-fold (0.00 log units), on the high side; measured number inside the range.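

Compound 3 puts an exact number on the 2-hydroxyethyl side chain with the 4-fluorophenyl group kept, and in this assay the change from hydroxymethyl reads as an at least 1.0-fold lower number from compound 2 to compound 3 (0.01 log units; that floor lies within the scatter). Compound 2 has only a limit and not a number, so that step is a floor and does not give the true size of the change: the limit of > 113000 nM in this assay, at which 1 of the 3 values shown sits.

With the 5-(2-hydroxyethyl)-4-methyl-1,3-thiazol-2-yl group held constant, the swap of 3-fluoro-4-methylphenyl for 4-fluorophenyl on an amide-type nitrogen gives a 1.3-fold higher number from compound 1 to compound 3 (0.11 log units; within the scatter), so this change shows no effect that can be told apart from the usual spread of repeat measurements.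

Going by these compounds, how far compound 2 really differs from compound 3 stays open, since an exact reading for compound 2 is lacking. The compounds shown also leave open how a longer chain such as 3-hydroxypropyl, or an amine or a carboxylic acid in place of the hydroxy on the saturated chain carbon bound to an aromatic carbon, would read in this assay.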